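The compounds below may be only part of what the source reports. "The series", "measured", "known", "first", "only" and "open" are said of these compounds alone.

Compound 1 `COc1cc2c(cc1OC)C(CC(=O)N(C)C)CC2` and compound 2 `COc1cc2c(cc1OC)C(CC(=O)NC(C)(C)C)CC2` share one core and differ only in the group on the carbonyl carbon. In a functional assay on the whole organism (strain Wistar) for inhibition, with Rattus norvegicus as the target, read by paw edema, with stated times of 60 min and 3 h, at a dose of 100 mg/kg by the oral route (on this read-out higher numbers stand for more inhibition at the one dose given (going by the name of the read-out) and lower numbers for less inhibition), compound 1 gives 34.8%, and compound 2 gives 33.3%; the step of a number 1.5 percentage points lower from compound 1 to compound 2 (within the scatter) is the only one measured. Compound 2 stands nearest compound 1, the two within the scatter of each other. Compound 3 `COc1cc2c(cc1OC)C(CC(=O)N1CCNCC1)CC2` brings (piperazin-1-yl in place of (tert-butyl)amino on a carbonyl carbon). Within the data shown here, since the one measured change at this position moved nothing beyond the scatter, no step beyond it is expected here: the expected step is a number 0.3 percentage points lower from compound 2 to compound 3 (within the scatter). Compound 3 is therefore estimated at 33%, within a range from 20% to 46%.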

Compound 3, a percentage reported as inhibition, in the whole organism at one dose (the size of the read-out at that dose, not a potency): 42%
Estimate against measurement, compound 3: 9 percentage points below; the range from low to high includes it.
By their numbers in this assay, from the lowest: compounds 2, 1 and 3 (each within the scatter of the next).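

Unlike dimethylamino and (tert-butyl)amino, piperazin-1-yl brings a six-membered ring and a second nitrogen onto the carbonyl carbon. In this assay this gives a number 8.7 percentage points higher from compound 2 to compound 3 (within the scatter) and a number 7.2 percentage points higher from compound 1 to compound 3 (within the scatter) so even this larger change in the type of amine leaves all three compounds within the usual scatter of one another. No measurement shown here offers an explanation for these numbers.

Still open, as far as these compounds go, is whether morpholine in place of piperazin-1-yl would give a step beyond the scatter. The same question stands for a carboxylic acid on this carbonyl carbon.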